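The source may report more compounds than this note shows. Statements on the series, on what has been measured and on what is new or still open speak of the compounds shown alone.

Measured compounds in the series:

Compound 1, `COc1cc(C(=O)/C=C\Nc2ccc(-c3nc4cc(OC)c(OC)c(OC)c4s3)cc2)c(Br)c(OC)c1OC`; in a functional assay on A549 cells (Homo sapiens) for antiproliferative activity, read by sulforhodamine B assay, with a stated time of 48 h (on this read-out lower numbers stand for stronger inhibition and higher numbers for weaker inhibition), compound 1 gives 13600 nM.
Compound 2, `COc1cc(OC)c2sc(-c3ccc(N/C=C\C(=O)c4ccc(OC)c(F)c4)c(C)c3)nc2c1`; in this assay compound 2 gives 15300 nM.
Compound 3, `COc1ccc2nc(-c3ccc(N/C=C\C(=O)c4ccc(OC)c(F)c4)cc3)sc2c1`; in this assay compound 3 gives 900 nM.

Compound 2 carries the highest number of the three. Compound 1 lies within the scatter of compound 2, so no order between those two can be read from the numbers. Compound 3 stands far lower than compound 2, and that gap is beyond the scatter.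

Compound 4, `COc1cc(OC)c2sc(-c3ccc(N/C=C\C(=O)c4ccc(OC)c([N+](=O)[O-])c4)c(C)c3)nc2c1`, is the next compound for this assay and has not yet been measured there. It differs from compound 2 in one place: nitro in place of fluoro on an aromatic carbon. Among the compounds with values here, no measured pair in the set carries this same change, so the data show nothing about its size or direction. Compound 2 sits at the high end of the numbers, and the change is a single substituent on the aromatic carbon ortho to the methoxy group with the rest of the molecule kept.

The step of a 1.3-fold lower number from compound 2 to compound 4 (0.11 log units; within the scatter) is expected to be small, in no preferred direction, and most likely not beyond the scatter. Compound 4 is accordingly expected to give about 12000 nM in this assay, estimated within the range 4000 nM to 40000 nM.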

Compound 4, half-maximal inhibitory concentration: 12100 nM
Compound 4: the middle estimate sits 1.0-fold (0.00 log units) below what was measured; measured number inside the range.
By their numbers in this assay, from the lowest: compound 3; then compounds 4, 1 and 2 (each within the scatter of the next).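

In this assay, within the data shown here, the 3-fluoro-4-methoxyphenyl to 4-methoxy-3-nitrophenyl exchange gives a 1.3-fold lower number from compound 2 to compound 4 (0.10 log units; within the scatter), the first step between compounds that differ in one place. On this aromatic carbon, ortho to a methoxy group, and with the rest of the molecule kept, the numbers therefore do not separate fluoro from nitro, even though nitro brings more heavy atoms and hydrogen-bond acceptors where fluoro has none. No measurement is available that bears on why the read-out stays within the scatter for this exchange.

As far as these compounds go, this single pair sits at the high end of the numbers in this assay, so it remains open whether the same exchange would also stay within the scatter on the core of compound 3 or of compound 1. From the compounds shown here alone, it is also open whether an amine, a carboxylic acid or a plain hydrogen on this same carbon would stay within the scatter of compound 2, or would move the number beyond it in either direction.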